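A few compounds are considered here, and "the series" means these few. Any claim that something is new, unique, unknown or untested is made for them only; others in the source may bear on it.

Measured compounds: compound 1 `CN(CC1CCN(CCCc2c[nH]c3ccc(-n4cnnc4)cc23)CC1)C(=O)Nc1ccccc1`, compound 2 `CN(Cc1ccco1)C1CCN(CCCc2c[nH]c3ccc(-n4cnnc4)cc23)CC1`, compound 3 `c1ccc(NCC2CCN(CCCc3c[nH]c4ccc(-n5cnnc5)cc34)CC2)nc1`.

In an assay on CHO cells for displacement of a labelled ligand from 5-hydroxytryptamine receptor 1D (Homo sapiens) (on this read-out higher numbers stand for weaker inhibition and lower numbers for stronger inhibition), compound 1 gives 5.9 nM, compound 2 gives 9.3 nM, and compound 3 gives 1.7 nM. Compound 1 thus holds the second highest number of the three, close to compound 2 and clearly above compound 3.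

Compound 4 `c1ccc2c(c1)CCC2NCC1CCN(CCCc2c[nH]c3ccc(-n4cnnc4)cc23)CC1` differs from compound 1 by (2,3-dihydro-1H-inden-1-yl)amino in place of methyl(phenylcarbamoyl)amino on a saturated chain carbon bound to a saturated ring carbon. The step that bears on this is a 3.5-fold lower number from compound 1 to compound 3 (0.54 log units; beyond the scatter), where another amino group bearing a ring replaced the same methyl(phenylcarbamoyl)amino group. The step of a 5.5-fold lower number from compound 2 to compound 3 (0.74 log units; beyond the scatter) points the same way. A modest drop is therefore expected, a 2.0-fold lower number from compound 1 to compound 4 (0.29 log units; within the scatter), so compound 4 is estimated at 3 nM, within 1 nM to 9 nM.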

Compound 4, half-maximal inhibitory concentration: 1.1 nM
Estimate against measurement, compound 4: 2.7-fold (0.44 log units) above; the range from low to high includes it.
By their numbers in this assay, from the lowest: compounds 4 and 3 (each within the scatter of the next); then compounds 1 and 2 (each within the scatter of the next).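

Here (2,3-dihydro-1H-inden-1-yl)amino on the saturated chain carbon gives a 5.4-fold lower number from compound 1 to compound 4 (0.73 log units; beyond the scatter) and, against the other parent, an 8.5-fold lower number from compound 2 to compound 4 (0.93 log units; beyond the scatter) in this assay. On the amine nitrogen, 2,3-dihydro-1H-inden-1-yl in place of pyridin-2-yl gives a 1.5-fold lower number from compound 3 to compound 4 (0.19 log units; within the scatter) with no ring nitrogen present, so among these compounds the low numbers do not depend on the pyridine ring. Nothing measured here gives a reason for these steps. On these data alone, it remains open whether a larger group on that nitrogen, such as 1,2,3,4-tetrahydronaphthalen-1-yl, keeps such numbers, and whether adding a methyl to that nitrogen does.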